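A few compounds are considered here, and "the series" means these few. Any claim that something is new, unique, unknown or untested is made for them only; others in the source may bear on it.

Measured compounds:
- compound 1 `CN1CCN(Cc2ccc(NC(=O)Nc3ccc4ncnc(Nc5ccc(F)c(Cl)c5)c4c3)cc2)CC1` — in a functional assay on A549 cells (Homo sapiens) for antiproliferative activity, read by MTT assay, with a stated time of 72 h (a higher number here means a weaker inhibitor, a lower number a stronger inhibitor), compound 1 gives 3480 nM
- compound 2 `CN1CCN(Cc2ccc(NC(=O)Nc3ccc4ncnc(Nc5cccc(C(F)(F)F)c5)c4c3)cc2)CC1` — in this assay compound 2 gives 1650 nM
- compound 3 `O=C(Nc1ccc(CN2CCCCC2)cc1)Nc1ccc2ncnc(Nc3cccc(C(F)(F)F)c3)c2c1` — in this assay compound 3 gives 1050 nM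

Compound 3 holds the lowest number of the three, but its gap to compound 2 is within the scatter; only its gap to compound 1 is beyond it, so it cannot be called the strongest inhibitor outright. The two steps seen so far: a 2.1-fold lower number from compound 1 to compound 2 (0.32 log units; beyond the scatter) and a 1.6-fold lower number from compound 2 to compound 3 (0.20 log units; within the scatter).

Compound 4 `CCN(CC)Cc1ccc(NC(=O)Nc2ccc3ncnc(Nc4cccc(C(F)(F)F)c4)c3c2)cc1` is not yet measured. It differs from compound 3 in one place: diethylamino in place of piperidin-1-yl on a saturated chain carbon bound to an aromatic carbon. The step that bears on it is the change at the same saturated chain carbon, a 1.6-fold lower number from compound 2 to compound 3 (0.20 log units; within the scatter), which stayed within the scatter. A second exchange of the amine at this position is therefore expected to move the number little, in either direction, with no change beyond the scatter as the most likely outcome. The expected step is a 1.1-fold higher number from compound 3 to compound 4 (0.06 log units; within the scatter). For compound 4 in this assay the estimate is 1200 nM, with a range from 500 nM to 3000 nM.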

Compound 4, half-maximal inhibitory concentration: 2070 nM
Beside the measured number, compound 4's estimate is 1.7-fold (0.24 log units) below it; the range from low to high includes it.
By their numbers in this assay, from the lowest: compounds 3, 2, 4 and 1 (each within the scatter of the next, the first and the last beyond it).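

In this assay, on the saturated chain carbon bound to an aromatic carbon, diethylamino in place of piperidin-1-yl gives a 2.0-fold higher number from compound 3 to compound 4 (0.29 log units; within the scatter) and diethylamino in place of 4-methylpiperazin-1-yl gives a 1.3-fold higher number from compound 2 to compound 4 (0.10 log units; within the scatter) as the two steps to the new compound. Compound 4 carries no ring in this amine, unlike compound 2 and compound 3, yet neither step lies beyond the scatter, so among these three compounds the six-membered non-aromatic ring is not required to keep the number within the scatter of the ring-bearing amines. No measurement in hand accounts for the size of either step, and the reading stays an observation on these three compounds only.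

Still open, going by these compounds, is whether this position stays as undemanding once the amine itself is replaced, for example by a hydroxyl or a carboxylic acid on the same chain carbon, or once a longer chain separates the amine from the aromatic ring. Also open, on these data alone, is whether diethylamino gives the same picture with 3-chloro-4-fluorophenyl in place of 3-(trifluoromethyl)phenyl on the nitrogen on an aromatic ring.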